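The source may report more compounds than this note shows. Statements on the series, on what has been measured and on what is new or still open speak of the compounds shown alone.

The measured compounds:
compound 1 `Cc1c(OCCCCOc2ccccc2C(=O)O)ccc(C(=O)CC2CCCC2)c1C`: 28%
compound 2 `Cc1c(OCCCCOc2ccccc2C(=O)O)ccc(C(=O)CC2CCCC2)c1O`: 32.9%
compound 3 `COc1ccc(C(=O)O)cc1OCCCCOc1ccc(C(=O)CC(C)C)c(O)c1C`: 100%

In an assay on HEK293 cells for positive allosteric modulation of metabotropic glutamate receptor 3 (Rattus norvegicus), read by thallium flux, with a stated time of 2.5 min (on this read-out lower numbers stand for smaller maximal responses and higher numbers for larger maximal responses), compound 1 gives 28%, the lowest of the three numbers. The nearest number is reached a number 4.9 percentage points higher from compound 1 to compound 2 (within the scatter), while compound 3 stands furthest away, beyond the scatter.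

Compound 4 `Cc1c(OCCCCOc2ccc(C(=O)O)c(Cl)c2)ccc(C(=O)CC2CCCC2)c1C` has not yet been measured. It differs from compound 1 in one place: 4-carboxy-3-chlorophenyl in place of 2-carboxyphenyl on an oxygen on a saturated carbon. Among the compounds with values here, the only measured single step, hydroxy in place of methyl on an aromatic carbon, gives a number 4.9 percentage points higher from compound 1 to compound 2 (within the scatter) and leaves the carboxyphenyl end untouched, so no measured step bears directly on the change in compound 4. Within the data shown here, compound 3 differs from compound 1 in several places at once; compound 3 gives 100%, but no single step connects the two. On this thin footing a rise in this assay is expected, though with wide uncertainty. Compound 4 is estimated at 60%, between 30% and 95%. This estimate means an expected step of a number 32 percentage points higher from compound 1 to compound 4 (beyond the scatter).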

Compound 4, largest response reached (reported as percent of maximum), in percent of the reference or control that the assay uses: 35.5%
Beside the measured number, compound 4's estimate is 24.5 percentage points above it, within the range that was stated.
By their numbers in this assay, from the lowest: compounds 1, 2 and 4 (each within the scatter of the next); then compound 3.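

In this assay the exchange of 2-carboxyphenyl for 4-carboxy-3-chlorophenyl on the oxygen gives a number 7.5 percentage points higher from compound 1 to compound 4 (within the scatter) on the shared core. Within the data shown here, this is the first reading at the carboxyphenyl end, which the earlier single step left untouched, and in this one pair the two aryl groups cannot be told apart by their maximal response. Nothing measured here accounts for this result.

The exchange brings in the chlorine and alters the place of the carboxylic acid in a single step, so this pair does not separate the two; 4-carboxyphenyl without the chlorine would be needed to part them. As far as these compounds go, it also remains open how a bromine in place of that chlorine, or a tetrazole in place of the carboxylic acid, would read out on this core.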